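Carbamate variation on the shared core: compound 2 to compound 3

This account rests on a few compounds, and the source may have more. Where it says the series, first, only, none or still open, it means among the compounds named here.

Working notes on a small set sharing one core. Compound 1 `C=C1C(=O)O[C@H]2[C@H]1CC/C(COC(=O)Nc1n[nH]c(SC)n1)=C\CC[C@@]1(C)O[C@@H]21` carries a carbamate bearing a methylthio-triazolyl group; in a functional assay on OVCAR-3 cells (Homo sapiens) for inhibition (a lower number here means a stronger inhibitor of growth, a higher number a weaker inhibitor of growth), compound 1 gives "not determined" (no result reported), so it contributes no number here. Going by the values given here, compound 2 `C=C1C(=O)O[C@H]2[C@H]1CC/C(COC(=O)N1CCC(F)(F)CC1)=C\CC[C@@]1(C)O[C@@H]21` is the only member with a value: in this assay compound 2 gives 1690 nM, the sole number in the set, with compound 1 standing beside it without one.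

Compound 3 `C=C1C(=O)O[C@H]2[C@H]1CC/C(COC(=O)NCCN1CCCC1)=C\CC[C@@]1(C)O[C@@H]21` keeps the core and the carbamate and differs from compound 2 only at the carbamate nitrogen ((2-(pyrrolidin-1-yl)ethyl)amino in place of 4,4-difluoropiperidin-1-yl on a carbonyl carbon). Among the compounds with values here, no measured pair of compounds shows how such a change moves the read-out. The expected step is modest, towards a lower number, and may not exceed the usual scatter; the estimate for the step is a 1.7-fold lower number from compound 2 to compound 3 (0.23 log units; within the scatter). Compound 3 is expected to give 1000 nM in this assay, with a range from 300 nM to 4000 nM.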

Compound 3, concentration for 50% growth inhibition: 8410 nM
Compound 3: middle estimate off by 8.4-fold (0.92 log units), on the low side; the whole stated range lies below it.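

Going by these compounds alone, this is the first measured step at the carbamate nitrogen. In this assay, (2-(pyrrolidin-1-yl)ethyl)amino in place of 4,4-difluoropiperidin-1-yl on a carbonyl carbon gives a 5.0-fold higher number from compound 2 to compound 3 (0.70 log units; beyond the scatter), so this position does respond to the change. Both groups count the same number of heavy atoms, so that count alone does not set the read-out here, and nothing available accounts for the step.

With only one step, the compounds shown leave open which part of the exchange carries it: the fluorine atoms, the ring, the chain or the hydrogen on the carbamate nitrogen. Plain piperidin-1-yl would isolate the fluorine atoms, while a longer chain ending in the same pyrrolidine or a dimethylamine would test the entering side.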